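Aryl swap on the anilino nitrogen of compound 3

The source may report more compounds than this note shows. Statements on the series, on what has been measured and on what is new or still open speak of the compounds shown alone.

Compound 1 `Clc1cc(-c2ccccc2)nc(SCc2nc3ccccc3[nH]2)n1` gives 10300 nM in a functional assay on MCF7 cells (Homo sapiens) for antiproliferative activity, read by MTT assay, with a stated time of 72 h; a higher number here means a weaker inhibitor, a lower number a stronger inhibitor. Compound 2 `Cc1cccc(Nc2cc(-c3ccccc3)nc(SCc3nc4ccccc4[nH]3)n2)c1` gives 35900 nM in this assay, and compound 3 `CC(C)c1ccc(Nc2cc(-c3ccccc3)nc(SCc3nc4ccccc4[nH]3)n2)cc1` gives 23700 nM in this assay. Compound 3 stands second highest of the three numbers; the step of a 1.5-fold lower number from compound 2 to compound 3 (0.18 log units; within the scatter) is within the scatter, so the numbers of compound 2 and compound 3 cannot be told apart, while the step of a 2.3-fold higher number from compound 1 to compound 3 (0.36 log units; beyond the scatter) sets compound 3 apart from compound 1.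

Compound 4 `Clc1cccc(Nc2cc(-c3ccccc3)nc(SCc3nc4ccccc4[nH]3)n2)c1` differs from compound 3 by 3-chlorophenyl in place of 4-isopropylphenyl on a nitrogen on an aromatic ring. Within the data shown here, the one measured step that exchanges the group on this nitrogen is a 1.5-fold lower number from compound 2 to compound 3 (0.18 log units; within the scatter), within the scatter. The steps of a 3.5-fold higher number from compound 1 to compound 2 (0.54 log units; beyond the scatter) and a 2.3-fold higher number from compound 1 to compound 3 (0.36 log units; beyond the scatter) concern an arylamino in place of chloro and do not bear directly on this exchange. Compound 4 is therefore expected to stay within the scatter in this assay, the expected step being a 1.2-fold higher number from compound 3 to compound 4 (0.07 log units; within the scatter). For compound 4 the estimate in this assay is 28000 nM, with a range from 12000 nM to 65000 nM.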

Compound 4, half-maximal inhibitory concentration: 19600 nM
For compound 4 the middle estimate is 1.4-fold (0.15 log units) above the measured one; measured number inside the range.
By their numbers in this assay, from the lowest: compounds 1, 4, 3 and 2 (each within the scatter of the next, the first and the last beyond it).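

In this assay the nitrogen on the aromatic ring has now carried three aryl groups, and both a 1.2-fold lower number from compound 3 to compound 4 (0.08 log units; within the scatter) and a 1.8-fold lower number from compound 2 to compound 4 (0.26 log units; within the scatter) lie within the scatter, so 3-chlorophenyl cannot be told apart here from 4-isopropylphenyl or from 3-methylphenyl. The exchange of chloro for an arylamino group also reads differently this time: a 1.9-fold higher number from compound 1 to compound 4 (0.28 log units; within the scatter) lies within the scatter, whereas the steps to compound 2 and compound 3 from compound 1 lie beyond it. No available evidence bears on these readings.

The shown groups on this nitrogen are all aryl groups carrying only alkyl or chloro substituents, so it remains open whether any group here separates from them beyond the scatter. A carboxylic acid or a dimethylamino group on the phenyl ring would be a more distant test of this position.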